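Methoxy scan on the anilino ring of the triazole series

The compounds below may be only part of what the source reports. "The series", "measured", "known", "first", "only" and "open" are said of these compounds alone.

Measured so far:
- compound 1, `COc1cccc(Nc2n[nH]c(-c3cccnc3Nc3cc(OC)cc(OC)c3)n2)c1`: 72%
- compound 2, `COc1cc(Nc2ncccc2-c2nc(Nc3cc(OC)ccc3OC)n[nH]2)cc(OC)c1`: 20%
- compound 3, `COc1cccc(Nc2n[nH]c(-c3cccnc3Oc3cc(OC)cc(OC)c3)n2)c1`: 83%

In a functional assay on A-431 cells (Homo sapiens), tested at 0.1 uM (on this read-out higher numbers stand for more inhibition at the one concentration tested (going by the name of the read-out) and lower numbers for less inhibition), compound 1 gives 72%. Compound 2 carries one more methoxy, (methoxy in place of hydrogen on an aromatic carbon), placed ortho to a large group and para to a methoxy group, and the step is a number 52 percentage points lower from compound 1 to compound 2 (beyond the scatter). Compound 3 differs from compound 1 in the core; the difference between the two cores is not broken down here. In this assay compound 3 gives 83%, the highest of the three.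

Compound 4, `COc1cc(Nc2n[nH]c(-c3cccnc3Oc3cc(OC)cc(OC)c3)n2)cc(OC)c1`, is not yet measured. It stands to compound 3 as compound 2 stands to compound 1, (methoxy in place of hydrogen on an aromatic carbon), but the place is not the same: here the entering methoxy sits meta to a large group and meta to a methoxy group, so this is the same kind of change, not the same one. Going by the values given here, the only measured step of this kind, the large fall seen in a number 52 percentage points lower from compound 1 to compound 2 (beyond the scatter), came with the other placement, so a smaller fall is expected for compound 4, a number 18 percentage points lower from compound 3 to compound 4 (beyond the scatter). Compound 4 is estimated at 65%, with a range from 40% to 85%.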

Compound 4, a percentage reported as inhibition, at one concentration (the size of the read-out at that concentration, not a potency): 87%
Estimate against measurement, compound 4: 22 percentage points below; measured number above the stated range.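

On the core of compound 3, in this assay, the step reads as a number 4 percentage points higher from compound 3 to compound 4 (within the scatter), so with a methoxy meta to a large group and meta to a methoxy group the number on this core is level at the one concentration tested. Set beside the earlier step, the change does not carry from one core to the other as a single effect: the same change on two cores in this assay, a number 52 percentage points lower (beyond the scatter) from compound 1 to compound 2 and a number 4 percentage points higher (within the scatter) from compound 3 to compound 4, 56 percentage points apart, beyond the scatter of two such steps. This does not show that the core alone sets the outcome: the entering methoxy also sits at a different place in the two steps, and one step on each core cannot separate the difference in core from the difference in place.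

Open, going by these compounds, is whether each placement would give the same result on the other core, the placement in compound 4 on the core of compound 1 and the placement in compound 2 on the core of compound 3. Also open, on these data alone, is how groups other than methoxy behave on the anilino ring, for example an amine, a fluorine or a longer chain such as ethoxy.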